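This account rests on a few compounds, and the source may have more. Where it says the series, first, only, none or still open, it means among the compounds named here.

Compounds measured so far:

Compound 1, `CN(Cc1ccc(S(C)(=O)=O)cc1)C1CCN(CCCc2c[nH]c3ccc(-n4cnnc4)cc23)CC1` — 140 nM
Compound 2, `CN(CC1CCN(CCCc2c[nH]c3ccc(-n4cnnc4)cc23)CC1)C(=O)Nc1ccccc1` — 6.2 nM
Compound 3, `CNS(=O)(=O)Cc1ccc2[nH]cc(CCCN3CCC(N[C@H](C)c4ccccc4)CC3)c2c1` — 260 nM

All three were tested in an assay on CHO cells for displacement of a labelled ligand from 5-hydroxytryptamine receptor 1B (Homo sapiens); on this read-out higher numbers stand for weaker inhibition and lower numbers for stronger inhibition. Compound 1 sits second highest of the three numbers. Its nearest neighbour is compound 3, whose value lies within the usual scatter of compound 1, so no order between these two can be read. Compound 2 stands far apart: its value against that of compound 1 shows a gap well beyond the scatter, with compound 2 on the stronger side.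

The piece now follows a single change from compound 1 to compound 4, `CN(C1CCN(CCCc2c[nH]c3ccc(-n4cnnc4)cc23)CC1)S(=O)(=O)c1ccccc1`, which has not yet been measured in this assay. The difference is phenylsulfonyl in place of 4-(methylsulfonyl)benzyl on an amine nitrogen. For the measured compounds named here, no measured pair of compounds shares this change, so nothing in the data shows how this assay responds to it. The author therefore expects a modest step, if any, and leans slightly toward a lower number, because compound 1 gives 140 nM and leaves room in either direction.

The estimated step from compound 1 to compound 4 is a 1.4-fold lower number from compound 1 to compound 4 (0.15 log units; within the scatter), and the expected value for compound 4 is 100 nM, with a range from 25 nM to 400 nM.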

Compound 4, half-maximal inhibitory concentration: 10 nM
For compound 4 the middle estimate is 10-fold (1.00 log units) above the measured one; the measured number lies below the stated range.
By their numbers in this assay, from the lowest: compounds 2 and 4 (each within the scatter of the next); then compounds 1 and 3 (each within the scatter of the next).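

In this assay, phenylsulfonyl in place of 4-(methylsulfonyl)benzyl on the amine nitrogen gives a 14-fold lower number from compound 1 to compound 4 (1.15 log units; beyond the scatter) and is a large step beyond the scatter, the first sign that the number responds strongly to what this nitrogen carries. The step appears even though the two groups match in what is counted for them: each has one six-membered aromatic ring of carbon only, the same double bonds outside aromatic rings, the same hydrogen-bond donors and acceptors, and no net charge, so these counts do not predict the size of the change. No measurement among the data offers an explanation for the step.

The single pair changes several features at once, so the compounds shown cannot separate the loss of the methylsulfonyl from the change in how the aromatic ring is joined to the nitrogen; a plain benzyl or a 4-(methylsulfonyl)phenylsulfonyl at this place would pull these apart. On these data alone, it also stays open whether the sulfonyl itself matters or whether a benzoyl, with a carbonyl in its place, would give a similar number.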